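Working notes: from compound 2 to compound 3

A few compounds are considered here, and "the series" means these few. Any claim that something is new, unique, unknown or untested is made for them only; others in the source may bear on it.

In an ADME assay on RAW264.7 cells (Mus musculus) for cytotoxicity, read by trypan blue exclusion, with a stated time of 48 h (a lower number here means a stronger inhibitor of growth, a higher number a weaker inhibitor of growth), compound 1 (`Cc1cc(CN2CCN(C3C[C@@H]4CC[C@H]3C4)CC2)c(C)n1-c1ccc(Cl)cc1`) gives 5.6 ug/mL and compound 2 (`Cc1cc(CN2CCN(c3ccccc3)CC2)c(C)n1-c1ccc(Cl)cc1`) gives 33 ug/mL, the higher of the two numbers. Compound 3 (`Cc1c(CN2CCN(c3ccccc3)CC2)cc(-c2ccc(Cl)cc2)n1-c1ccc(Cl)cc1`) carries 4-chlorophenyl in place of methyl on an aromatic carbon. Among the measured compounds shown here, the only measured step, a 5.9-fold higher number from compound 1 to compound 2 (0.77 log units; beyond the scatter), lies on an amine nitrogen in a ring, so it suggests a size but not a direction for this change. A modest move toward a lower number is expected, with the estimated step being a 2.1-fold lower number from compound 2 to compound 3 (0.31 log units; beyond the scatter). Compound 3 is expected at 16 ug/mL, within an estimated range of 5 ug/mL to 50 ug/mL.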

Compound 3, concentration for 50% growth inhibition: 175 ug/mL
Compound 3: middle estimate off by 11-fold (1.04 log units), on the low side; the measured number lies above the stated range.
By their numbers in this assay, from the lowest: compound 1; then compound 2; then compound 3.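

In this assay, 4-chlorophenyl in place of methyl on this aromatic carbon, next to the ring nitrogen, gives a 5.3-fold higher number from compound 2 to compound 3 (0.72 log units; beyond the scatter) and so a weaker inhibitor of growth. The number therefore responds to a change on the five-membered aromatic ring, not only to the earlier change on an amine nitrogen in a ring. Nothing available explains this rise.

With only methyl and 4-chlorophenyl shown here, an unsubstituted phenyl or an ethyl group could separate the effect of the chlorine from that of size. As far as these compounds go, whether the same exchange behaves alike with the amine substituent of compound 1 remains open.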